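Toxicity limits and a chlorophenyl swap on compound 1

This account rests on a few compounds, and the source may have more. Where it says the series, first, only, none or still open, it means among the compounds named here.

In a toxicity assay on THP-1 cells (Homo sapiens) for inhibition (on this read-out higher numbers stand for lower toxicity in this test and lower numbers for higher toxicity in this test), compound 1 (`Cc1ccccc1C(=O)Nc1ncc(-c2ccccc2)n1C`) gives > 100000 nM, which is a limit of the assay and not a number. Compound 1 therefore stands at the limit of > 100000 nM in this assay, at which 2 of the 3 values shown sit. Compound 2 (`COc1ccc(-c2cn(C)c(NC(=O)c3ccc(F)cc3)n2)cc1`) gives > 50000 nM, also a limit. Compound 3 (`COc1ccc(-c2ccc(NC(=O)c3ccc(F)cc3)nc2)cc1`) gives > 100000 nM, again a limit. Compound 4 (`Cn1c(-c2ccccc2)cnc1NC(=O)c1ccc(Cl)cc1`) keeps the core of compound 1 and carries 4-chlorophenyl in place of 2-methylphenyl on a carbonyl carbon. Among the compounds with values here, the series offers no measured step for this change, and no shift beyond the scatter is expected in this assay. The estimated a number no higher from compound 1 to compound 4 (the limit leaves the size open) is expected to stay within the scatter. Compound 4 is expected at 100000 nM, with an estimated range of 40000 nM to 200000 nM.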

Compound 4, half-maximal cytotoxic concentration: > 100000 nM
Compound 4 gave a limit, no number; the forecaster's own chance of this, stated with the estimate: 85%; the middle value lies on the limit itself.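

Compound 1 and compound 4 both give limits, so no step can be read for 4-chlorophenyl in place of 2-methylphenyl. The compounds shown leave open how any of them ranks in this assay.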